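This account rests on a few compounds, and the source may have more. Where it says the series, first, only, none or still open, it means among the compounds named here.

The opening of this account concerns four compounds that share a core and differ in where a nitro group sits. Compound 1, `O=[N+]([O-])c1ccc(Cn2cc(COc3ccccc3)nn2)cc1`, carries a nitro group on one ring of the core, and in a physicochemical assay, read by spectrophotometry, with a stated time of 30 min (on this read-out lower numbers stand for stronger inhibition and higher numbers for weaker inhibition), compound 1 gives 10.1 ug/mL. Compound 2, `O=[N+]([O-])c1cccc(Cn2cc(COc3ccccc3)nn2)c1`, is built from the same atoms as compound 1, joined differently; the difference between the two cores is not broken down here. In this assay, among the compounds with values here, compound 2 gives 25.3 ug/mL, the highest of the three numbers measured so far, beyond the scatter from compound 1 but within it from compound 3.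

Compound 3, `O=[N+]([O-])c1ccc(Cn2cc(COc3cccc([N+](=O)[O-])c3)nn2)cc1`, differs from compound 1 by nitro in place of hydrogen on an aromatic carbon. In this assay compound 3 gives 17.1 ug/mL, and the step of a 1.7-fold higher number from compound 1 to compound 3 (0.23 log units; within the scatter) lies within the scatter of repeated measurements.

Compound 4, `O=[N+]([O-])c1cccc(Cn2cc(COc3cccc([N+](=O)[O-])c3)nn2)c1`, has not yet been measured. It differs from compound 2 by nitro in place of hydrogen on an aromatic carbon. This is the same change that was made from compound 1 to compound 3, at a place that reads the same. The account expects a step of a 1.6-fold higher number from compound 2 to compound 4 (0.20 log units; within the scatter) in this assay, of about the size seen in a 1.7-fold higher number from compound 1 to compound 3 (0.23 log units; within the scatter), a step that rests on a single measured pair and is itself within the scatter, so little shift is expected. On that basis compound 4 is estimated to give 40 ug/mL in this assay, with a likely range from 20 ug/mL to 80 ug/mL.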

Compound 4, half-maximal inhibitory concentration: 19.1 ug/mL
Compound 4: middle estimate off by 2.1-fold (0.32 log units), on the high side; measured number below the stated range.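

On the core of compound 2, nitro in place of hydrogen on an aromatic carbon gives a 1.3-fold lower number from compound 2 to compound 4 (0.12 log units; within the scatter) in this assay and on the core of compound 1 the same change gives a 1.7-fold higher number from compound 1 to compound 3 (0.23 log units; within the scatter) so on both cores the step stays inside what repeated measurements would scatter by. Within the data shown here, the printed steps point in opposite directions, but neither can be read as a real shift, so the two pairs show only that carrying this change from one core to the other produced no step that stands clear of the scatter on either core; they do not show that the change acts alike on the two cores, nor that it acts differently. Nothing shown here bears on why the numbers on the two cores fall where they do.

The compounds shown leave open how a group other than nitro would read at this place on either core, for instance an amine or a carboxylic acid. Among these compounds, they also leave open whether a step beyond the scatter can be reached at all on these cores, since only two matched pairs, both carrying the same change, stand behind this account.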